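Linker extension in a tricyclic bicyclooctane series

The source may hold more compounds than are shown below. What is called first, only, known or untested is meant among the compounds shown, and "the series" means these compounds.

Measured so far:
compound 1 `CCCn1c(=O)c2[nH]c(C34CCC(C(=O)NCCNC(=O)COCCOCCNC(=O)OC(C)(C)C)(CC3)CC4)nc2n(CCC)c1=O`: 17.4 nM
compound 2 `CCCn1c(=O)c2[nH]c(C34CCC(C(=O)NCCCNC(=O)COCCNC(=O)OC(C)(C)C)(CC3)CC4)nc2n(CCC)c1=O`: 16.2 nM

Both compounds share the same core and differ only in the chain that carries the terminal carbamate. Among the measured compounds shown here, in an assay on Flp-In-CHO cells for displacement of a labelled ligand from adenosine receptor A1 (Homo sapiens), read by radioligand binding (a higher number here means a weaker inhibitor, a lower number a stronger inhibitor), compound 2 gives 16.2 nM, and the only comparison available, compound 1 in this assay at 17.4 nM, cannot be separated from it, so compound 2 has no distinct standing among the two numbers.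

Compound 3 `CCCn1c(=O)c2[nH]c(C34CCC(C(=O)NCCCNC(=O)COCCOCCNC(=O)OC(C)(C)C)(CC3)CC4)nc2n(CCC)c1=O` is the next member. Relative to compound 2 the change is 2-((tert-butoxycarbonyl)amino)ethoxy in place of (tert-butoxycarbonyl)amino on a saturated chain carbon, two bonds along the chain from an oxygen on a saturated carbon. Compound 3 thus carries the longer ether chain already present in compound 1 together with the diamine of compound 2; both of those chains gave indistinguishable numbers, and no step beyond the scatter has been seen in this pair. The expectation for the step from compound 2 to compound 3 is therefore none beyond the scatter, a 1.0-fold higher number from compound 2 to compound 3 (0.02 log units; within the scatter). Compound 3 is expected to read 17 nM in this assay, estimated between 9 nM and 34 nM.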

Compound 3, inhibition constant: 22.4 nM
The estimate for compound 3 lay 1.3-fold (0.12 log units) below the measured number, within the range that was stated.
By their numbers in this assay, from the lowest: compounds 2, 1 and 3 (each within the scatter of the next).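

Working notes on the chain: in this assay the one readable step so far is a 1.4-fold higher number from compound 2 to compound 3 (0.14 log units; within the scatter) and it gives the first direct view of this position. Placing 2-((tert-butoxycarbonyl)amino)ethoxy in place of (tert-butoxycarbonyl)amino, on a saturated chain carbon, two bonds along the chain from an oxygen on a saturated carbon, takes the group from 8 to 11 heavy atoms and adds one oxygen, yet compound 2 and compound 3 cannot be separated; at this position, and with this carbamate end kept, the added ethoxy unit leaves no readable mark on the number. No measurement at hand bears on why the number stays within the scatter across this change.

All three compounds shown end in the same tert-butoxycarbonyl carbamate, so it remains open how a free primary amine or a carboxylic acid at the chain end would read. It is equally open whether a longer chain with further ethoxy units, or a much shorter chain, would still sit within the scatter of these compounds.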